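Triazole Oxime Ethers of a Triterpenoid Ketone in HeLa Cells

A few compounds are considered here, and "the series" means these few. Any claim that something is new, unique, unknown or untested is made for them only; others in the source may bear on it.

The parent ketone, compound 1 `CC(C)=CCC/C(C)=C/CC/C(C)=C/CC[C@@H]1[C@@]2(C)CCC(=O)C(C)(C)[C@@H]2CC[C@@]1(C)O`, was tested in a functional assay on HeLa cells (Homo sapiens) for cytotoxicity, read by MTT assay, with a stated time of 48 h (a higher number here means a weaker inhibitor, a lower number a stronger inhibitor), where compound 1 gives 18300 nM. Its oxime ether carrying a triazole with a 2-cyanophenyl group, compound 2 `CC(C)=CCC/C(C)=C/CC/C(C)=C/CC[C@@H]1[C@@]2(C)CC/C(=N\OCc3cn(-c4ccccc4C#N)nn3)C(C)(C)[C@@H]2CC[C@@]1(C)O`, gives 21200 nM in this assay. Among the two measured numbers, compound 2 stands alongside compound 1, the gap between them lying within the usual scatter, so the two cannot be ordered.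

Compound 3 `COc1cc(OC)c(-n2cc(CO/N=C3\CC[C@]4(C)[C@@H](CC/C=C(\C)CC/C=C(\C)CCC=C(C)C)[C@](C)(O)CC[C@H]4C3(C)C)nn2)c(OC)c1` has not yet been measured. It differs from compound 2 in one place: 2,4,6-trimethoxyphenyl in place of 2-cyanophenyl on an aromatic nitrogen. Among the compounds with values here, no measured pair shows what such a change does here. Since compound 1 and compound 2 sit within the scatter of each other, no step beyond the scatter is expected in this assay, and the step of a 1.3-fold lower number from compound 2 to compound 3 (0.12 log units; within the scatter) is estimated as small in either direction. Compound 3 is therefore expected to give about 16000 nM in this assay, within a range from 6000 nM to 45000 nM.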

Compound 3, half-maximal inhibitory concentration: 12800 nM
Estimate against measurement, compound 3: 1.3-fold (0.10 log units) above; the measured number falls inside the stated range.
By their numbers in this assay, from the lowest: compounds 3, 1 and 2 (each within the scatter of the next).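

In this assay, within the data shown here, the exchange of 2-cyanophenyl for 2,4,6-trimethoxyphenyl on the aromatic nitrogen of the triazole gives a 1.7-fold lower number from compound 2 to compound 3 (0.22 log units; within the scatter), the first step that can be read at this position. Two different aryl groups, one bearing a nitrile and the other bearing methoxy groups, therefore sit on this nitrogen without a difference that can be read beyond the scatter. No supporting measurement bears on this result.

The compounds shown leave open whether any group on this nitrogen can move the number beyond the scatter, as only these two aryl groups can be set side by side. An aryl group bearing an amine or a carboxylic acid, or a longer alkyl chain in place of the aryl group, remains an open case at this position.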